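A few compounds are considered here, and "the series" means these few. Any claim that something is new, unique, unknown or untested is made for them only; others in the source may bear on it.

Of the compounds shown here, two of the shared core have been measured in a functional assay on aorta (Rattus norvegicus) for inhibition; on this read-out lower numbers stand for an effect already at smaller amounts and higher numbers for an effect only at larger amounts of compound. Compound 1 `CCOC(=O)c1c(C)[nH]c(=O)c(C#N)c1-c1ccncc1` gives 270000 nM, whereas compound 2 `CCOC(=O)c1c(C)[nH]c(=O)c(C#N)c1-c1ccc([N+](=O)[O-])cc1` gives 7000 nM, the lowest of the two numbers and a step that lies beyond the usual scatter. Compound 3 `CCOC(=O)c1c(C)[nH]c(=O)c(C#N)c1-c1ccc([N+](=O)[O-])cc1[N+](=O)[O-]` is not yet measured; it differs from compound 2 by nitro in place of hydrogen on an aromatic carbon. Going by the values given here, no step between measured compounds shows what a nitro in place of hydrogen does on this core, so the step from compound 2 to compound 3 is expected to be small, near or within the scatter, as a 1.4-fold higher number from compound 2 to compound 3 (0.15 log units; within the scatter). For compound 3 the expected value in this assay is 10000 nM, with a range from 2000 nM to 50000 nM.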

Compound 3, half-maximal effective concentration: 4400 nM
For compound 3 the middle estimate is 2.3-fold (0.36 log units) above the measured one; the measured number falls inside the stated range.
By their numbers in this assay, from the lowest: compounds 3 and 2 (each within the scatter of the next); then compound 1.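

In this assay this aromatic carbon, ortho to a large group and meta to a nitro group, accepts a nitro in place of hydrogen, with a 1.6-fold lower number from compound 2 to compound 3 (0.20 log units; within the scatter) and so no separation of the two compounds beyond the scatter. Going by these compounds alone, this is the first reading of any change at this position, and it shows that the added nitro, with its 3 heavy atoms, leaves the number essentially where it was. Nothing measured here explains this result. Open, going by these compounds, is whether an amine, a methoxy group or a carboxylic acid at this carbon would also leave the number unchanged. Also open, on these data alone, is how the number responds when the existing nitro is replaced by a chlorine or a nitrile.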